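A few compounds are considered here, and "the series" means these few. Any claim that something is new, unique, unknown or untested is made for them only; others in the source may bear on it.

Compound 1, `COc1ccccc1CNc1ncnc2c1ncn2[C@@H]1O[C@H](CO)[C@@H](O)[C@H]1O`, gives 2300 nM in a functional assay on HL-60 cells (Homo sapiens) for antiproliferative activity, with a stated time of 72 h; on this read-out higher numbers stand for weaker inhibition and lower numbers for stronger inhibition. Compound 2, `COc1cccc(CNc2ncnc3c2ncn3[C@@H]2O[C@H](CO)[C@@H](O)[C@H]2O)c1`, gives 4900 nM.

Compound 2 stands highest of the two measured numbers in this assay; its nearest neighbour is compound 1, separated by a 2.1-fold higher number from compound 1 to compound 2 (0.33 log units; beyond the scatter). Compound 3, `OC[C@H]1O[C@@H](n2cnc3c(NCc4ccc(F)cc4Cl)ncnc32)[C@H](O)[C@@H]1O`, differs from compound 2 by 2-chloro-4-fluorophenyl in place of 3-methoxyphenyl on a saturated chain carbon bound to a nitrogen on an aromatic ring. Within the data shown here, the only measured step, a 2.1-fold higher number from compound 1 to compound 2 (0.33 log units; beyond the scatter), set 3-methoxyphenyl in place of 2-methoxyphenyl rather than exchanging a methoxyphenyl for a halogenated ring, so it bears on this change only loosely and gives no clear direction. Compound 3 is therefore expected to remain near compound 2, with a 1.4-fold lower number from compound 2 to compound 3 (0.15 log units; within the scatter). The estimate for compound 3 is 3500 nM, ranging from 1000 nM to 12000 nM.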

Compound 3, half-maximal inhibitory concentration: 9000 nM
Compound 3: the middle estimate sits 2.6-fold (0.41 log units) below what was measured; measured number inside the range.
By their numbers in this assay, from the lowest: compound 1; then compounds 2 and 3 (each within the scatter of the next).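

In this assay, the halogenated ring at this position, on a saturated chain carbon bound to a nitrogen on an aromatic ring, gives a 1.8-fold higher number from compound 2 to compound 3 (0.26 log units; within the scatter), so the exchange of 3-methoxyphenyl for 2-chloro-4-fluorophenyl cannot be told apart from no effect. Against 2-methoxyphenyl the same ring gives a 3.9-fold higher number from compound 1 to compound 3 (0.59 log units; beyond the scatter), which leaves compound 1 with the lowest number of the three. Nothing available explains these differences. The compounds shown leave open whether the chlorine or the fluorine matters on its own, and how an unsubstituted phenyl, an amine on the ring or a longer chain would read.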